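Replacing Chloro with Fluoro on the Aromatic Ring

A few compounds are considered here, and "the series" means these few. Any claim that something is new, unique, unknown or untested is made for them only; others in the source may bear on it.

Three compounds have been measured in a functional assay on RAW264.7 cells (Mus musculus), read by fluorescence; a higher number here means a weaker inhibitor, a lower number a stronger inhibitor:
- compound 1 `CCOC(=O)C1=CCCCC1S(=O)(=O)Cc1ccccc1F`: 97 nM
- compound 2 `CCOC(=O)C1=CCCCC1S(=O)(=O)Cc1cccc(Cl)c1`: 14 nM
- compound 3 `CCOC(=O)C1=CCCCC1S(=O)(=O)Cc1cccc(Cl)c1F`: 12 nM

Compound 3 gives the lowest number of the three, although compound 2 sits within the scatter of it, so the two cannot be ordered; compound 1 stands clearly apart, with an 8.1-fold lower number from compound 1 to compound 3 (0.91 log units; beyond the scatter).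

Compound 4 `CCOC(=O)C1=CCCCC1S(=O)(=O)Cc1cccc(F)c1F` has not yet been measured. It differs from compound 3 in one place: fluoro in place of chloro on an aromatic carbon. Two measured steps speak to this change. The step of an 8.1-fold lower number from compound 1 to compound 3 (0.91 log units; beyond the scatter) shows what putting chloro onto that aromatic carbon did; compound 4 keeps the position occupied, but by fluoro instead. The step of a 1.2-fold lower number from compound 2 to compound 3 (0.07 log units; within the scatter) shows that adding a fluoro on the other aromatic carbon changed little. Within the data shown here, there is no measured step that shows fluoro at the carbon in question directly. A fluoro in place of chloro is therefore expected to give back part, but not all, of the gain seen between compound 1 and compound 3, so a modest rise in this assay is expected, a 2.5-fold higher number from compound 3 to compound 4 (0.40 log units; beyond the scatter).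

Compound 4 is thus estimated at 30 nM, with a range from 10 nM to 90 nM.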

Compound 4, half-maximal inhibitory concentration: 100 nM
Beside the measured number, compound 4's estimate is 3.3-fold (0.52 log units) below it, outside the stated range (above it).
By their numbers in this assay, from the lowest: compounds 3 and 2 (each within the scatter of the next); then compounds 1 and 4 (each within the scatter of the next).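

At this aromatic carbon, chloro and fluoro are far from interchangeable in this assay: the swap costs nearly all of the strength, with an 8.3-fold higher number from compound 3 to compound 4 (0.92 log units; beyond the scatter). Fluoro at this carbon also cannot be told apart from the hydrogen it replaces, with a 1.0-fold higher number from compound 1 to compound 4 (0.01 log units; within the scatter), so the gain that earlier looked tied to filling this position now belongs to chloro, not to any small halogen placed there. Among the compounds shown, the low numbers go with chloro at this carbon, while adding fluoro in place of hydrogen makes no difference that can be read, whichever compound receives it: the same change on two cores in this assay, a 1.2-fold lower number (0.07 log units; within the scatter) from compound 2 to compound 3 and a 1.0-fold higher number (0.01 log units; within the scatter) from compound 1 to compound 4, 1.2-fold (0.08 log units) apart, within the scatter of two such steps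

On these data alone, what remains open is whether chloro is special at this carbon, or whether a bromo, methyl or trifluoromethyl group there would also give a low number. All the chloro compounds shown also carry it on this one carbon, so what a chloro would do elsewhere on the aromatic ring is unknown.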